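Amino to Dimethylamino on the Aromatic Carbon

The compounds below may be only part of what the source reports. "The series", "measured", "known", "first", "only" and "open" are said of these compounds alone.

Compound 1: `CC(/C=N/Nc1ccc([N+](=O)[O-])cc1)=N\NC(=O)c1ccccc1F` — > 12000 nM
Compound 2: `CC(/C=N/Nc1ccc([N+](=O)[O-])cc1)=N\NC(=O)c1ccc(N)cc1` — > 12000 nM

In a functional assay on cells (Splenocyte, Mus musculus, strain BALB/c) for inhibition, read by scintillation counting and thymidine incorporation, with a stated time of 72 h (on this read-out lower numbers stand for stronger inhibition and higher numbers for weaker inhibition), compound 1 gives > 12000 nM, which is a limit of the assay rather than a number. Compound 2 likewise gives > 12000 nM, again a limit. The step that the two limits leave unreadable from compound 1 to compound 2 is therefore unreadable, and compound 2 stands at the limit of > 12000 nM in this assay, at which 2 of the 2 values shown sit, with no number of its own.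

Compound 3, `CC(/C=N/Nc1ccc([N+](=O)[O-])cc1)=N\NC(=O)c1ccc(N(C)C)cc1`, differs from compound 2 by dimethylamino in place of amino on an aromatic carbon. For the measured compounds named here, no measured step bears on this change, and the values offer no direction. The step expected is a step that the limit leaves unreadable from compound 2 to compound 3, likely leaving compound 3 at a limit. Compound 3 is estimated at 15000 nM, within 5000 nM to 40000 nM.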

Compound 3, half-maximal inhibitory concentration: > 12000 nM
Compound 3 gave a limit, no number; the forecaster's own chance of this, stated with the estimate: 75%; the middle value lies beyond the limit too.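

Compound 3 gives > 12000 nM, which is a limit of the assay and not a number. No new step can be read among compound 1, compound 2 and compound 3. The compounds shown leave open whether dimethylamino in place of amino alters inhibition at all.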